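Swapping a carbamate for a selenium-bearing aryl group

The compounds below may be only part of what the source reports. "The series", "measured", "known", "first", "only" and "open" are said of these compounds alone.

Compound 2 `CC1=C([Se]CC(OC(=O)CNC(=O)OC(C)(C)C)C(=O)NCCCCCC(=O)OCc2ccccc2)C(=O)c2ccccc2C1=O` carries the shared core with a tert-butoxycarbonylamino group on its ester-linked chain. In a functional assay on A498 cells (Homo sapiens) for cytotoxicity, read by MTT assay, with a stated time of 24 h (a higher number here means a weaker inhibitor, a lower number a stronger inhibitor), compound 2 gives 7000 nM, the highest of the two numbers shown. Its neighbour compound 1 `CC1=C([Se]CC(OC(=O)[C@@H](CO)NC(=O)OC(C)(C)C)C(=O)NCCCCCC(=O)OCc2ccccc2)C(=O)c2ccccc2C1=O` gives 5000 nM, and the step of a 1.4-fold higher number from compound 1 to compound 2 (0.15 log units; within the scatter) lies within the scatter. Compound 3 `CC1=C(SCCC(=O)OC(C[Se]c2ccccc2)C(=O)NC(C)(C)C)C(=O)c2ccccc2C1=O` reaches only the limit of this assay, > 100000 nM. The unmeasured compound 4 `CC1=C([Se]CC(OC(=O)CC[Se]c2ccccc2)C(=O)NCCCCCC(=O)OCc2ccccc2)C(=O)c2ccccc2C1=O` differs from compound 2 by a group of 8 heavy atoms (7 carbon, 1 selenium; one six-membered aromatic ring of carbon only) in place of a group of 8 heavy atoms (5 carbon, 1 nitrogen, 2 oxygen; no ring), on a saturated chain carbon bound to a carbonyl carbon. Among the measured compounds shown here, no measured step touches this position; the single step shown sits elsewhere, and the limit of > 100000 nM in this assay, at which 1 of the 3 values shown sits, belongs to compound 3, which differs in many places. Compound 4 is therefore expected near compound 2, at 10000 nM (from 3000 nM to 40000 nM), an expected step of a 1.4-fold higher number from compound 2 to compound 4 (0.15 log units; within the scatter).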

Compound 4, half-maximal inhibitory concentration: 4000 nM
Beside the measured number, compound 4's estimate is 2.5-fold (0.40 log units) above it, and the stated range covers the measured number.
By their numbers in this assay, from the lowest: compounds 4, 1 and 2 (each within the scatter of the next). At a limit, above all of these: compound 3.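

At the saturated chain carbon bound to a carbonyl carbon, the (tert-butoxycarbonyl)amino group gives way to a selenium-bearing aryl group without a shift beyond the scatter in this assay, with a 1.8-fold lower number from compound 2 to compound 4 (0.24 log units; within the scatter). The wider exchange on the carbonyl carbon also stays within the scatter, with a 1.3-fold lower number from compound 1 to compound 4 (0.10 log units; within the scatter), so this position accepts an aromatic ring in place of the open-chain groups. Nothing measured here bears on why these values stay level. The compounds shown leave open whether an amine or a carboxylic acid at this position would keep this level, and the same holds for a longer chain carrying the selenium.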